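The source may report more compounds than this note shows. Statements on the series, on what has been measured and on what is new or still open speak of the compounds shown alone.

Values measured so far in an ADME assay on cells (Macrophage) for cytotoxicity, read by MTT assay, with a stated time of 24 h (on this read-out lower numbers stand for higher toxicity in this test and higher numbers for lower toxicity in this test), are these:

compound 1 `O=C(/C=C/c1cccc([N+](=O)[O-])c1)NNC(=O)c1ccc2c(c1)OCCO2` gives 323000 nM
compound 2 `O=C(/C=C/c1ccccc1)NNC(=O)c1ccc2c(c1)OCCO2` gives 312000 nM
compound 3 `COc1ccccc1/C=C/C(=O)NNC(=O)c1ccc2c(c1)OCCO2` gives 312000 nM

These three values lie within the usual scatter of one another, so compound 1 stands level with the other two and not apart from them.

The next step leads from compound 1 to compound 4 `Cc1cccc(/C=C/C(=O)NNC(=O)c2ccc3c(c2)OCCO3)c1` by placing methyl in place of nitro on an aromatic carbon, meta to a large group (methyl in place of nitro on an aromatic carbon), which turns 3-nitrophenyl into 3-methylphenyl.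

Among the measured compounds shown here, three measured steps bear on this change. Hydrogen in place of that same nitro gave a 1.0-fold lower number from compound 1 to compound 2 (0.02 log units; within the scatter) and is the closest comparison. 2-methoxyphenyl in place of 3-nitrophenyl gave a 1.0-fold lower number from compound 1 to compound 3 (0.02 log units; within the scatter) and methoxy in place of hydrogen gave no change at the digits printed from compound 2 to compound 3 (within the scatter) on the same series. None of these steps left the scatter. On that footing, no step beyond the scatter is expected in this assay for the methyl group, in either direction. The expected step is a 1.0-fold lower number from compound 1 to compound 4 (0.02 log units; within the scatter) and nothing larger is foreseen. For compound 4 the estimated value is 312000 nM with an expected range from 180000 nM to 520000 nM in this read-out.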

Compound 4, half-maximal cytotoxic concentration: 281000 nM
The estimate for compound 4 lay 1.1-fold (0.05 log units) above the measured number; measured number inside the range.
By their numbers in this assay, from the lowest: compounds 4, 2, 3 and 1 (each within the scatter of the next).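

In this assay, among the compounds shown here, the earlier compounds held only nitro and hydrogen at this position, and methyl now extends that set: replacing nitro with methyl gives a 1.1-fold lower number from compound 1 to compound 4 (0.06 log units; within the scatter), and replacing hydrogen with methyl gives a 1.1-fold lower number from compound 2 to compound 4 (0.05 log units; within the scatter). Nitro counts two hydrogen-bond acceptors and methyl none, yet this difference leaves the number within the scatter, and the change from 2-methoxyphenyl to 3-methylphenyl, a 1.1-fold lower number from compound 3 to compound 4 (0.05 log units; within the scatter), also stays within it. No measurement here explains why these numbers stay level.

No change shown so far moves the number beyond the scatter, so what would do so remains unknown. As far as these compounds go, whether an amine, a carboxylic acid or a longer chain at this place would do so stays open, as does the effect of any change to the shared core.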